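Swapping the aryl cap on a piperazine-linked oxazole

The compounds below may be only part of what the source reports. "The series", "measured", "known", "first", "only" and "open" are said of these compounds alone.

Measured so far:
Compound 1 `CCCc1nc(-c2ccccc2)c(CNCCCN2CCN(c3ccc(F)cc3)CC2)o1` — 3210 nM
Compound 2 `CCCc1nc(-c2ccccc2)c(CNCCN2CCN(c3ccc(C(F)(F)F)cc3)CC2)o1` — 1300 nM

Both compounds were tested in an assay on HEK293 cells for inhibition of Voltage-dependent T-type calcium channel subunit alpha-1G (Homo sapiens), read by patch clamp; on this read-out lower numbers stand for stronger inhibition and higher numbers for weaker inhibition. Compound 1 gives 3210 nM, the higher of the two numbers, and so the weaker inhibition shown here. Compound 2 gives 1300 nM, a gap that lies beyond the usual scatter. The two compounds differ in more than one place, however, so no single structural change can be tied to that gap.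

Compound 3 `CCCc1nc(-c2ccccc2)c(CNCCCN2CCN(c3cccc(C)c3)CC2)o1` is not yet measured. It keeps the shared core of compound 1 and changes only the aryl group on the piperazine ring: 3-methylphenyl in place of 4-fluorophenyl on an amine nitrogen in a ring. The group that leaves and the group that enters are of equal size and carry neither donors nor acceptors.

Nothing in the measured pair speaks directly to this exchange, so no step beyond the scatter is expected in this assay; the estimated step from compound 1 to compound 3 is a 1.3-fold lower number from compound 1 to compound 3 (0.11 log units; within the scatter). Compound 3 is expected to give about 2500 nM, within a range from 800 nM to 8000 nM.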

Compound 3, half-maximal inhibitory concentration: 1190 nM
For compound 3 the middle estimate is 2.1-fold (0.32 log units) above the measured one; low and high end bracket the measured number.
By their numbers in this assay, from the lowest: compounds 3 and 2 (each within the scatter of the next); then compound 1.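

Going by these compounds alone, this is the first comparison here that differs in one place only, and it shows that the aryl group on an amine nitrogen in a ring can shift the result in this assay. Putting 3-methylphenyl in place of 4-fluorophenyl gives a 2.7-fold lower number from compound 1 to compound 3 (0.43 log units; beyond the scatter) and so moves the number by a modest but real amount. The two groups match in several counted features, with 7 heavy atoms each and 0 hydrogen-bond donors or acceptors, yet the number still moves. No measurement available here explains what lies behind this step.

The exchange alters both the substituent and its place on the phenyl ring, so the effects of these two changes cannot yet be pulled apart; 4-methylphenyl and 3-fluorophenyl would be the groups to separate them. Also open, on these data alone, is how 4-trifluoromethylphenyl would read on the chain of compound 1, a comparison that would connect compound 2, which still differs from the other two compounds in more than one place.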